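Swapping a hydroxyphenyl for a chlorophenyl in a hydrazone anticonvulsant

The source may report more compounds than this note shows. Statements on the series, on what has been measured and on what is new or still open speak of the compounds shown alone.

Of the compounds shown here, three have so far been tested in a functional assay on the whole organism with Mus musculus as the target, in the maximal electroshock model, with a stated time of 0.5 h; a higher number here means that more compound is needed for the effect, a lower number that less compound is needed. Compound 1, `Cc1ccc(NC(=S)Nc2ccc(S(=O)(=O)Nc3ccc(C)cc3)cc2)cc1`, and compound 2, `O=c1snc(Nc2ccccn2)n1-c1ccccn1`, are quite different structures; in this assay compound 1 needs 300 mg/kg, and compound 2 also needs 300 mg/kg. Compound 3, `CCOc1ccc(NC(=O)N/N=C(\C)c2ccccc2O)cc1`, stands lowest of the three numbers, needing 100 mg/kg in this assay, which puts it beyond the usual scatter from both compound 1 and compound 2, each of which shows a higher number.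

Compound 4, `CCOc1ccc(NC(=O)N/N=C(\C)c2ccc(Cl)cc2)cc1`, has not yet been measured. It differs from compound 3 in one place: 4-chlorophenyl in place of 2-hydroxyphenyl on a carbon with a double bond to nitrogen. The group that leaves carries a hydrogen-bond donor and an acceptor; the group that enters carries neither. Going by the values given here, no pair of measured compounds here differs in a single place, so there is no measured step to lean on for this kind of change. With only the value of compound 3 at 100 mg/kg as an anchor, the step from compound 3 to compound 4 is expected to stay within the scatter, no change at the digits printed from compound 3 to compound 4 (within the scatter). Compound 4 is therefore estimated to need about 100 mg/kg in this assay, somewhere between 50 mg/kg and 300 mg/kg.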

Compound 4, minimum effective dose: 300 mg/kg
Estimate against measurement, compound 4: 3.0-fold (0.48 log units) below; the range from low to high includes it.
By their numbers in this assay, from the lowest: compound 3; then compounds 1, 2 and 4 (each within the scatter of the next).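

Going by these compounds alone, this is the first measured step at this position, the carbon with a double bond to nitrogen. In this assay, 4-chlorophenyl in place of 2-hydroxyphenyl gives a 3.0-fold higher number from compound 3 to compound 4 (0.48 log units; beyond the scatter), a modest change but one beyond the scatter, so what this carbon carries does matter. The two groups have the same heavy-atom count and the same aromatic ring, but only 2-hydroxyphenyl carries a hydrogen-bond donor and acceptor, and no measurement here accounts for the step.

This single change replaces the hydroxyl with chlorine and also alters where the substituent sits on the ring, so the compounds shown cannot separate those two parts. As far as these compounds go, whether plain phenyl or an aminophenyl group on this carbon would fall nearer compound 3 or compound 4 also remains open.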